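The source may hold more compounds than are shown below. What is called first, only, known or untested is meant among the compounds shown, and "the series" means these compounds.

Compound 3 `CC1=CC[C@@H]([C@@](C)(O)CCCC(C)(C)NC(=S)N/N=C\c2cccc([N+](=O)[O-])c2)CC1` gives 5600 nM in a functional assay on PCO3 cells (Homo sapiens) for cytotoxicity, read by sulforhodamine B assay (a lower number here means a stronger inhibitor of growth, a higher number a weaker inhibitor of growth), the lowest of the three numbers. Compound 2 `CC1=CC[C@@H]([C@@](C)(O)CCCC(C)(C)NC(=S)N/N=C\c2ccc(N(C)C)cc2)CC1` gives 13700 nM, and compound 1 `CC1=CC[C@@H]([C@@](C)(O)CCCC(C)(C)NC(=S)NN)CC1`, the smallest member of the set, gives 26800 nM. Compound 4 `CC1=CC[C@@H]([C@@](C)(O)CCCC(C)(C)NC(=S)N/N=C\c2ccc(Cl)cc2)CC1` differs from compound 3 by 4-chlorophenyl in place of 3-nitrophenyl on a carbon with a double bond to nitrogen. Within the data shown here, the one measured step that bears on this change is the earlier swap of the aromatic ring at the same position, a 2.4-fold lower number from compound 2 to compound 3 (0.39 log units; beyond the scatter), which shows that changing this ring moves this assay only modestly. No ring bearing chlorine has yet been measured here. The expected step is therefore a 1.4-fold higher number from compound 3 to compound 4 (0.15 log units; within the scatter), a shift that may not exceed the scatter. Compound 4 is estimated at 8000 nM, within a range from 3000 nM to 20000 nM.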

Compound 4, concentration for 50% growth inhibition: 7580 nM
Compound 4: the middle estimate sits 1.1-fold (0.02 log units) above what was measured; the range from low to high includes it.
By their numbers in this assay, from the lowest: compounds 3, 4, 2 and 1 (each within the scatter of the next, the first and the last beyond it).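

In this assay, 4-chlorophenyl can replace 3-nitrophenyl with no clear change (a 1.4-fold higher number from compound 3 to compound 4 (0.13 log units; within the scatter)), so the nitro group is not required for this level of growth inhibition. Chloro in place of dimethylamino also stays within the scatter (a 1.8-fold lower number from compound 2 to compound 4 (0.26 log units; within the scatter)), while adding the substituted ring to the bare end of compound 1 gives a real but modest gain (a 3.5-fold lower number from compound 1 to compound 4 (0.55 log units; beyond the scatter)). Nothing available explains these differences. From the compounds shown here alone, whether an amine or a carboxylic acid on the ring would move the number further remains open. So does whether a longer chain could take the ring's place.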